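Adding a hydroxy to the phenyl of compound 3

A few compounds are considered here, and "the series" means these few. Any claim that something is new, unique, unknown or untested is made for them only; others in the source may bear on it.

In a functional assay on HepG2 cells (Homo sapiens) for inhibition, read by MTT assay, with a stated time of 24 h (on this read-out lower numbers stand for stronger inhibition and higher numbers for weaker inhibition), compound 3 (`CC1(C)[C@H]2CC[C@]1(C)N(Cc1cn(-c3ccccc3)nn1)C(=O)C2`) gives 90 nM, level with compound 2 (`CC1(C)[C@H]2CC[C@]1(C)N(Cc1cn(-c3ccc(F)cc3)nn1)C(=O)C2`) at 90 nM. Among the measured compounds shown here, these two share the highest number of the three measured so far, while compound 1 (`CC1(C)[C@H]2CC[C@]1(C)N(Cc1cn(-c3cccc(C#N)c3)nn1)C(=O)C2`) stands lowest at 40 nM.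

Compound 4 (`CC1(C)[C@H]2CC[C@]1(C)N(Cc1cn(-c3cccc(O)c3)nn1)C(=O)C2`) turns the phenyl into 3-hydroxyphenyl, with hydroxy in place of hydrogen on an aromatic carbon.

For the measured compounds named here, two measured steps bear on this change. Replacing the cyano of the 3-cyanophenyl group with hydrogen gives a 2.3-fold higher number from compound 1 to compound 3 (0.35 log units; beyond the scatter), a modest step. Replacing fluoro with hydrogen gives no change at the digits printed from compound 2 to compound 3 (within the scatter), so a substituent on this ring does not always move the number. Going by the values given here, no measured compound carries hydroxy, which leaves the cyano step only a loose guide.

A small shift towards a lower number in this assay is therefore expected, possibly none beyond the scatter. The expected change is a 1.4-fold lower number from compound 3 to compound 4 (0.14 log units; within the scatter). For compound 4 the estimated value is 65 nM, with an expected range of 30 nM to 140 nM.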

Compound 4, half-maximal inhibitory concentration: 70 nM
Estimate against measurement, compound 4: 1.1-fold (0.03 log units) below; measured number inside the range.
By their numbers in this assay, from the lowest: compounds 1, 4, 2 and 3 (each within the scatter of the next, the first and the last beyond it).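

In this assay, hydroxy in place of hydrogen on the phenyl, meta to a large group, gives a 1.3-fold lower number from compound 3 to compound 4 (0.11 log units; within the scatter), so this substituent, with one hydrogen-bond donor and one acceptor, cannot be told apart from the unsubstituted ring. Set against the other substituted rings, the 3-hydroxyphenyl gives a 1.3-fold lower number from compound 2 to compound 4 (0.11 log units; within the scatter) and hydroxy in place of cyano gives a 1.8-fold higher number from compound 1 to compound 4 (0.24 log units; within the scatter), so compound 4 sits within the scatter of all three earlier compounds, although cyano alone of the substituents shown has a step to hydrogen beyond the scatter. No measurement at hand accounts for the size of these steps.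

From the compounds shown here alone, whether the cyano step reflects something specific to that group remains open. A methoxy group, an amine or a carboxylic acid at this same place would test how far the number can move.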